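This account rests on a few compounds, and the source may have more. Where it says the series, first, only, none or still open, it means among the compounds named here.

Working notes on the series. In a functional assay on WiDr cells (Homo sapiens) for antiproliferative activity, read by sulforhodamine B assay, with a stated time of 48 h (a lower number here means a stronger inhibitor of growth, a higher number a weaker inhibitor of growth), compound 1 `Cc1ccc(S(=O)(=O)N2CC[C@@H](Cl)C[C@@H]2c2ccccc2)cc1` gives 37000 nM and compound 2 `Cc1ccc(S(=O)(=O)N2CC[C@@H](Br)C[C@@H]2CC(C)C)cc1` gives 14000 nM. Compound 3 `Cc1ccc(S(=O)(=O)N2CC=C(Cl)CC2)cc1` gives only a limit in this assay, > 100000 nM. This places compound 3 at the weak end of the numbers seen so far, a point that carries little weight in itself because the limit of > 100000 nM in this assay, at which 1 of the 3 values shown sits, marks it as a boundary of the assay rather than a measured value. Compound 4 `CCCCCCCC1C=C(Cl)CCN1S(=O)(=O)c1ccc(C)cc1` has not yet been measured in this assay. It differs from compound 3 by heptyl in place of hydrogen on a saturated ring carbon. Compound 1 and compound 2, which both carry a group on the ring carbon next to the ring nitrogen, give measured numbers where compound 3 gives only a limit, so a chain entering at that place is expected to move compound 4 toward measurable growth inhibition. The step from compound 3 to compound 4 in this assay is therefore expected as a gain, an at least 5.0-fold lower number from compound 3 to compound 4 (0.69 log units; beyond the scatter). For compound 4 in this assay the estimate is 20000 nM, with a range from 6000 nM to 70000 nM.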

Compound 4, concentration for 50% growth inhibition: 50000 nM
Compound 4: middle estimate off by 2.5-fold (0.40 log units), on the low side; low and high end bracket the measured number.
By their numbers in this assay, from the lowest: compound 2; then compounds 1 and 4 (each within the scatter of the next). At a limit, above all of these: compound 3.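

In this assay, heptyl on a saturated ring carbon next to the ring nitrogen gives compound 4 a measured number, where the hydrogen at this place in compound 3 gives only a limit. The change reads as an at least 2.0-fold lower number from compound 3 to compound 4 (0.30 log units; that floor lies within the scatter), so a gain beyond the scatter is neither shown nor excluded. This step is only a floor because the value of compound 3 is a limit of the assay: the limit of > 100000 nM in this assay, at which 1 of the 4 values shown sits.

On these data alone, whether a shorter chain such as propyl, a longer chain such as decyl, or a chain carrying an amine or a carboxylic acid would give a lower or higher number at this place remains open. Also open, as far as these compounds go, is whether heptyl here would give a similar step with bromo in place of the chloro group.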